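This account rests on a few compounds, and the source may have more. Where it says the series, first, only, none or still open, it means among the compounds named here.

Measured so far:
compound 1, `Nc1nc(Cl)c2ncn(Cc3ccccc3CCl)c2n1`, 6610 nM in a functional assay on HCC 2998 cells (Homo sapiens) for cytotoxicity, read by sulforhodamine B assay, with a stated time of 48 h; on this read-out lower numbers stand for stronger inhibition of growth and higher numbers for weaker inhibition of growth
compound 2, `Nc1nc(Cl)c2ncn(Cc3cccc(CCl)c3)c2n1`, 4890 nM in this assay

Of the compounds shown here, two have been measured, and both carry the same core with a chloromethyl-bearing benzyl group, the two differing only in where that chloromethyl sits on the benzene ring. Of the two numbers, compound 1 gives the highest, and its nearest neighbour is compound 2, whose number is lower by a small margin that lies within the usual scatter of this assay, so the two cannot be told apart on these data.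

Compound 3, `ClCc1ccccc1Cn1cnc2c(Cl)ncnc21`, has not yet been measured. It differs from compound 1 in one place: hydrogen in place of amino on an aromatic carbon. For the measured compounds named here, no step between two measured compounds is available that would show what this kind of change does here. In the absence of such a step, the expected step of a 1.4-fold higher number from compound 1 to compound 3 (0.13 log units; within the scatter) is a modest rise in the number, though a result within the scatter would not be surprising. Compound 3 is therefore estimated at 9000 nM, with a likely range from 4000 nM to 25000 nM.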

Compound 3, concentration for total growth inhibition: 3540 nM
Estimate against measurement, compound 3: 2.5-fold (0.41 log units) above, outside the stated range (below it).
By their numbers in this assay, from the lowest: compounds 3, 2 and 1 (each within the scatter of the next).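

Putting hydrogen in place of amino on this aromatic carbon, which lies between two ring nitrogen atoms, gives a 1.9-fold lower number from compound 1 to compound 3 (0.27 log units; within the scatter) in this assay and so leaves the two compounds indistinguishable on these data. For the compounds shown here, this is the first single-place step, and it shows that compound 3 stays within the scatter of compound 1 even without the amino group and the hydrogen-bond donor and acceptor counted with it. Nothing measured here bears on why this swap makes so little visible difference.

The compounds shown leave open what other groups on this same aromatic carbon would do, such as a methylamino group, a dimethylamino group or a methoxy group, any of which would show whether this position tolerates more than hydrogen and amino. They also leave open whether hydrogen in place of amino reads the same way on compound 2, where the chloromethyl group sits elsewhere on the benzene ring, so this single step cannot yet be called a pattern.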